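From Compound 1 to Compound 4: a Piperidine Addition

The source may hold more compounds than are shown below. What is called first, only, known or untested is meant among the compounds shown, and "the series" means these compounds.

Measured so far:
- compound 1 `C[C@@H]1CN(c2sc(C(F)(F)F)nc2-c2nc3ccccc3[nH]2)CCN1C(=O)Cn1cccn1`: 191 nM
- compound 2 `Cc1nc(C)n(CC(=O)N2CCN(c3sc(C(F)(F)F)nc3-c3nc4ccc(C5CCOCC5)cc4[nH]3)C[C@H]2C)n1`: 123 nM
- compound 3 `Cc1nc(C)n(CC(=O)N2CCN(c3sc(C(F)(F)F)nc3-c3nc4ccc(OC5CNC5)cc4[nH]3)C[C@H]2C)n1`: 580 nM

In a functional assay on Venous blood for antagonist activity at C-X-C chemokine receptor type 3 (Homo sapiens), read by flow cytometry, with a stated time of 30 min, in the presence of a further agent that is not named here (a lower number here means a stronger inhibitor, a higher number a weaker inhibitor), compound 1 gives 191 nM, the second highest of the three numbers. Compound 2 sits nearest, within the scatter, while compound 3 lies furthest, beyond it. Within the data shown here, the only step in the set, a 4.7-fold higher number from compound 2 to compound 3 (0.67 log units; beyond the scatter), involves a change on the core's other aromatic ring and so does not speak directly to the change studied here.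

Compound 4 `C[C@@H]1CN(c2sc(C(F)(F)F)nc2-c2nc3ccccc3[nH]2)CCN1C(=O)Cn1cc(C2CCN(C)CC2)cn1` differs from compound 1 as follows: 1-methylpiperidin-4-yl in place of hydrogen on an aromatic carbon. The entering group is a six-membered non-aromatic ring carrying one nitrogen, attached on an aromatic carbon of the five-membered ring.

Among the measured compounds shown here, no measured pair tests this position, so the expectation rests on compound 1 alone. The step of a 1.2-fold lower number from compound 1 to compound 4 (0.08 log units; within the scatter) is expected to stay within the scatter. Compound 4 is therefore estimated at 160 nM in this assay, with a range from 50 nM to 500 nM.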

Compound 4, half-maximal inhibitory concentration: 1690 nM
Compound 4: middle estimate off by 11-fold (1.02 log units), on the low side; measured number outside the range, above it.
By their numbers in this assay, from the lowest: compounds 2 and 1 (each within the scatter of the next); then compound 3; then compound 4.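

In this assay, placing 1-methylpiperidin-4-yl on an aromatic carbon of the 1H-pyrazol-1-yl group gives an 8.8-fold higher number from compound 1 to compound 4 (0.95 log units; beyond the scatter), so the inhibitor becomes weaker. Among these compounds, this is the first measured change at this position, as the earlier step concerned a different part of the molecule, and it shows that this carbon does not accept every added group without a loss in this test. Nothing measured here explains the loss.

Among the compounds shown here, with only one group tested at this carbon, it remains open whether the ring itself, its nitrogen or the methyl on that nitrogen drives the change. A cyclohexyl ring, which has no nitrogen, or a single fluorine atom at the same carbon would help separate these possibilities by showing how far the result depends on the entering group.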